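Shifting a Chlorine: Expected Cytotoxicity of Compound 4

The source may report more compounds than this note shows. Statements on the series, on what has been measured and on what is new or still open speak of the compounds shown alone.

Compound 1, `COC(=O)c1cc(-c2cccc(NC(=O)c3ccc(/C=C/C(=O)c4cccc(F)c4)cc3)c2)on1`: in an ADME assay on Vero cells (Chlorocebus sabaeus) for cytotoxicity, read by MTT assay, with a stated time of 72 h (on this read-out lower numbers stand for higher toxicity in this test and higher numbers for lower toxicity in this test), compound 1 gives > 40 ug/mL, a limit of the assay.
Compound 2, `COC(=O)c1cc(-c2cccc(NC(=O)c3ccc(/C=C/C(=O)c4cc(F)ccc4F)cc3)c2)on1`: in this assay compound 2 gives > 40 ug/mL, again a limit.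
Compound 3, `COC(=O)c1cc(-c2cccc(NC(=O)c3ccc(/C=C/C(=O)c4ccc(Cl)cc4)cc3)c2)on1`: in this assay compound 3 gives > 50 ug/mL, also a limit.

For the measured compounds named here, compound 3 therefore stands on a limit, and the two other measured compounds stand on limits as well, so no compound can be placed above or below another. Compound 4, `COC(=O)c1cc(-c2cccc(NC(=O)c3ccc(/C=C/C(=O)c4ccccc4Cl)cc3)c2)on1`, has not yet been measured. It differs from compound 3 in one place: 2-chlorophenyl in place of 4-chlorophenyl on a carbonyl carbon.

Going by the values given here, three measured steps touch the same region. The step that the two limits leave unreadable from compound 1 to compound 3 and the step that the two limits leave unreadable from compound 2 to compound 3 exchange the group on the carbonyl carbon, and the step that the two limits leave unreadable from compound 1 to compound 2 adds a fluoro on that ring. None of them is readable in size, since every value sits on a limit: the limit of > 40 ug/mL in this assay, at which 2 of the 3 values shown sit, and (the limit of > 50 ug/mL in this assay, at which 1 of the 3 values shown sits). No step beyond the scatter is therefore expected from compound 3 to compound 4; the expected step is a step that the limit leaves unreadable from compound 3 to compound 4. Compound 4 is estimated to give about 60 ug/mL in this assay, within a range of 30 ug/mL to 200 ug/mL, most likely reported as a limit.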

Compound 4, half-maximal cytotoxic concentration: > 25 ug/mL
Compound 4: only a limit was reported (the forecaster's own chance of this, stated with the estimate: 85%); the middle value lies beyond the limit too.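

Compound 4 gives > 25 ug/mL in this assay, a limit of the assay. For the compounds shown here, no step between compound 4 and compound 1, compound 2 or compound 3 can be read, because all four values are limits: the limit of > 25 ug/mL in this assay, at which 1 of the 4 values shown sits. The compounds shown leave open whether 2-chlorophenyl in place of 4-chlorophenyl changes the cytotoxicity at all.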